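The compounds below may be only part of what the source reports. "The series", "measured", "known", "first", "only" and "open" are said of these compounds alone.

In a functional assay on Bel7402/5-FU cells (Homo sapiens) for antiproliferative activity, read by MTT assay, with a stated time of 72 h (on this read-out lower numbers stand for stronger inhibition and higher numbers for weaker inhibition), compound 1 `C=C1C(=O)O[C@H]2[C@H]1CC/C(Cn1cc(Cn3cc(F)c(=O)[nH]c3=O)nn1)=C\CC[C@@]1(C)O[C@@H]21` gives only a limit, > 20000 nM, with the limit of > 20000 nM in this assay, at which 1 of the 3 values shown sits, marking that ceiling. Among the measured compounds shown here, compound 2 `C=C1C(=O)O[C@H]2[C@H]1CC/C(Cn1cc(Cn3cc(F)c(=O)n(Cc4ccc(F)cc4)c3=O)nn1)=C\CC[C@@]1(C)O[C@@H]21` gives 4860 nM, and the step of an at least 4.1-fold lower number from compound 1 to compound 2 (0.61 log units; beyond the scatter) is the one measured change here. Compound 3 `C=C1C(=O)O[C@H]2[C@H]1CC/C(COC(=O)Cn1cc(F)c(=O)n(Cc3ccc(Br)cc3)c1=O)=C\CC[C@@]1(C)O[C@@H]21` gives 3240 nM, which sits within the scatter of compound 2, so the two cannot be ordered. Compound 4 `C=C1C(=O)O[C@H]2[C@H]1CC/C(COC(=O)Cn1cc(F)c(=O)n(CCC)c1=O)=C\CC[C@@]1(C)O[C@@H]21` differs from compound 3 by ethyl in place of 4-bromophenyl on a saturated chain carbon bound to an aromatic nitrogen. For the measured compounds named here, the only step on record runs the other way, adding an aryl group on the aromatic nitrogen; it reached at least modest size in this assay, so removing the 4-bromophenyl is expected to raise the number, though the limit on compound 1 leaves its full extent unknown. Compound 4 is therefore expected to give about 9000 nM in this assay, between 3000 nM and 25000 nM, a step of a 2.8-fold higher number from compound 3 to compound 4 (0.44 log units; beyond the scatter).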

Compound 4, half-maximal inhibitory concentration: 9110 nM
For compound 4 the middle estimate is 1.0-fold (0.01 log units) below the measured one; low and high end bracket the measured number.
By their numbers in this assay, from the lowest: compounds 3, 2 and 4 (each within the scatter of the next, the first and the last beyond it). At a limit, above all of these: compound 1.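

In this assay, among the compounds shown here, the group on this chain can be read on its own for the first time: with the rest of the molecule unchanged, the step of a 2.8-fold higher number from compound 3 to compound 4 (0.45 log units; beyond the scatter) is modest but lies beyond the scatter. In this single pair, then, 4-bromobenzyl gives the lower number and propyl the higher. Nothing measured here gives a reason for this step.

From the compounds shown here alone, whether the phenyl ring or its bromine carries the step remains open. So does how an unsubstituted benzyl, a longer chain such as hexyl, or a chain ending in an amine or a carboxylic acid would read at this position.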